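The compounds below may be only part of what the source reports. "The series", "measured", "known", "first", "only" and "open" are said of these compounds alone.

Working notes on the series.

Compound 3 `CC(C)(C)c1cc(-c2cc(=O)c3ccc(OCC(=O)N4CCCCC4)cc3o2)cc(C(C)(C)C)c1O`, compound 1 `CC(C)(C)c1cc(-c2cc(=O)c3ccc(OCC(=O)N4CCN(Cc5ccccc5)CC4)cc3o2)cc(C(C)(C)C)c1O` and compound 2 `CCN(CC)C(=O)COc1ccc2c(=O)cc(-c3cc(C(C)(C)C)c(O)c(C(C)(C)C)c3)oc2c1` share one core and differ only in the amide at the end of the chain on the aromatic oxygen. In a functional assay for inhibition (a higher number here means a weaker inhibitor, a lower number a stronger inhibitor), compound 3 gives 3000 nM, compound 1 gives 3000 nM and compound 2 gives 3000 nM; compound 3 stands level with both. Within the data shown here, the one step, no change at the digits printed from compound 2 to compound 3 (within the scatter), shows that exchanging the amine part of the amide leaves this assay unchanged.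

Compound 4 `CC(C)(C)c1cc(-c2cc(=O)c3ccc(OCCO)cc3o2)cc(C(C)(C)C)c1O` goes further: hydroxymethyl in place of (piperidin-1-yl)carbonyl on a saturated chain carbon bound to an oxygen on an aromatic ring. Here the amide carbonyl itself is lost, and no measured step covers that. Among the measured compounds shown here, the only step present, from compound 2 to compound 3, touched the amine side and was flat, which gives no sign that the chain end decides activity in this assay, but it also does not test the loss of the carbonyl. The expected step is therefore no change at the digits printed from compound 3 to compound 4 (within the scatter), with a wide range. For compound 4 the estimate in this assay is 3000 nM, expected to lie between 1000 nM and 10000 nM.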

Compound 4, half-maximal inhibitory concentration: 3000 nM
Beside the measured number, compound 4's estimate shows no gap at the digits printed; low and high end bracket the measured number.
By their numbers in this assay, from the lowest: compounds 1, 2, 3 and 4 (each within the scatter of the next).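

Working notes, continued.

Replacing the amide with hydroxymethyl on a saturated chain carbon bound to an oxygen on an aromatic ring gives no change at the digits printed from compound 3 to compound 4 (within the scatter) in this assay, and the same replacement gives no change at the digits printed from compound 2 to compound 4 (within the scatter) in this assay as well. The earlier step changed only the amine side, whereas these two steps remove the carbonyl and the whole amine part, so among these compounds the value in this assay does not depend on the amide being present. No available data explain this flat result.

Going by these compounds, since every change at this chain end has been flat so far, it remains open whether any group here can shift the value. A carboxylic acid or a primary amine at the chain end, or a longer chain, would test that.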